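The compounds below may be only part of what the source reports. "The series", "measured", "known", "first", "only" and "open" are said of these compounds alone.

Three compounds of the series have been run. Compound 1 `CCCCOc1cc(C(=O)NCC)nn1-c1ccccc1` gives 0% in a functional assay on the whole organism (strain Wistar) for inhibition, with Rattus norvegicus as the target, read by paw edema, with stated times of 30 min and 3 h, at a dose of 100 mg/kg by the oral route; on this read-out lower numbers stand for less inhibition and higher numbers for more inhibition at the one dose given (going by the name of the read-out). Compound 2 `CCCCNC(=O)c1cc(OCCCC)n(-c2ccccc2)n1` gives 43.3% in this assay, and compound 3 `CCCCOc1cc(C(=O)N(CC)CC)nn1-c1ccccc1` gives 44.1% in this assay. Compound 3 thus holds the highest of the three numbers, but its gap to compound 2 lies within the scatter, so the two cannot be ordered against each other; only compound 1 stands clearly apart. The steps of a number 43.3 percentage points higher from compound 1 to compound 2 (beyond the scatter) and a number 44.1 percentage points higher from compound 1 to compound 3 (beyond the scatter) are both large, whereas a number 0.8 percentage points higher from compound 2 to compound 3 (within the scatter) is not.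

Compound 4 `CCCCOc1cc(C(=O)NCCCN(C)C)nn1-c1ccccc1` has not yet been measured. (3-(dimethylamino)propyl)amino in place of diethylamino on a carbonyl carbon The measured step that bears most directly on this change is a number 0.8 percentage points higher from compound 2 to compound 3 (within the scatter), an exchange of one amide substituent for another of comparable size that left the number where it was; compound 4's entering group also carries a hydrogen-bond donor, as the butylamino group of compound 2 does. Among the measured compounds shown here, no measured step shows what the dimethylamino part of the entering group does in this assay. The expectation for compound 4 in this assay is therefore a number 4.1 percentage points lower from compound 3 to compound 4 (within the scatter), no movement beyond the scatter. Compound 4 is estimated at 40%, within 15% to 60%.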

Compound 4, a percentage reported as inhibition, in the whole organism at one dose (the size of the read-out at that dose, not a potency): 29.8%
The estimate for compound 4 lay 10.2 percentage points above the measured number, and the stated range covers the measured number.
By their numbers in this assay, from the lowest: compound 1; then compound 4; then compounds 2 and 3 (each within the scatter of the next).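

In this assay the amide substituent on the carbonyl carbon proves sensitive to exchange: (3-(dimethylamino)propyl)amino in place of diethylamino gives a number 14.3 percentage points lower from compound 3 to compound 4 (beyond the scatter), and dimethylamino in place of methyl on a saturated chain carbon, three bonds along the chain from an amide-type nitrogen, gives a number 13.5 percentage points lower from compound 2 to compound 4 (beyond the scatter), so both of the comparably high neighbours separate from the new compound beyond the scatter. Set against the ethylamino amide, (dimethylamino)methyl in place of hydrogen on a saturated chain carbon, two bonds along the chain from an amide-type nitrogen, still gives a number 29.8 percentage points higher from compound 1 to compound 4 (beyond the scatter), so the dimethylamino-bearing chain keeps part of the gain seen with butylamino and diethylamino but not all of it. No measurement in hand bears on what lies behind these movements.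

Open, on these data alone, is whether the lower number belongs to dimethylamino itself or would also appear with another amine on the same chain, such as morpholine or piperidine, or with a carboxylic acid there. As far as these compounds go, a longer chain carrying dimethylamino also remains untested in these compounds, and a single dose leaves the shape of any dose response unknown.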